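Triazole nitrogen substituent variation in the cinnamic acid series

A few compounds are considered here, and "the series" means these few. Any claim that something is new, unique, unknown or untested is made for them only; others in the source may bear on it.

Compound 3 `COc1ccc(/C=C\C(=O)O)c(OCc2cn(-c3ccc(CO)cc3)nn2)c1CC=C(C)C` gives 31700 nM in a functional assay on HCT-116 cells (Homo sapiens) for cytotoxicity, read by MTT assay, with a stated time of 24 h (on this read-out higher numbers stand for weaker inhibition and lower numbers for stronger inhibition), and stands second highest of the three numbers. Compound 1 `COc1ccccc1-n1cc(COc2c(/C=C\C(=O)O)ccc(OC)c2CC=C(C)C)nn1` gives 32200 nM and compound 2 `COc1ccc(-n2cc(COc3c(/C=C\C(=O)O)ccc(OC)c3CC=C(C)C)nn2)cc1` gives 8700 nM. All three differ only in the group on the aromatic nitrogen: a 3.7-fold lower number from compound 1 to compound 2 (0.57 log units; beyond the scatter) and a 3.6-fold higher number from compound 2 to compound 3 (0.56 log units; beyond the scatter) lie beyond the scatter, while a 1.0-fold lower number from compound 1 to compound 3 (0.01 log units; within the scatter) lies within it. Compound 4 `COc1ccc(/C=C\C(=O)O)c(OCc2cn(-c3nc4ccccc4s3)nn2)c1CC=C(C)C` carries 1,3-benzothiazol-2-yl in place of 4-(hydroxymethyl)phenyl on an aromatic nitrogen. For the measured compounds named here, no measured step covers this replacement, so the expected step of a 1.6-fold lower number from compound 3 to compound 4 (0.20 log units; within the scatter) is taken as small and not beyond the span already seen across the three aryl groups. Compound 4 is therefore expected to give 20000 nM, with a range from 6000 nM to 60000 nM.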

Compound 4, half-maximal inhibitory concentration: 16400 nM
Estimate against measurement, compound 4: 1.2-fold (0.09 log units) above; the range from low to high includes it.
By their numbers in this assay, from the lowest: compounds 2, 4, 3 and 1 (each within the scatter of the next, the first and the last beyond it).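

In this assay, for the compounds shown here, the 1,3-benzothiazol-2-yl group is the first on this nitrogen to bring a five-membered aromatic ring with 2 hetero atoms, and it shows a 1.9-fold lower number from compound 3 to compound 4 (0.29 log units; within the scatter) and a 1.9-fold higher number from compound 2 to compound 4 (0.28 log units; within the scatter) and a 2.0-fold lower number from compound 1 to compound 4 (0.29 log units; within the scatter) without leaving the scatter of any phenyl compound. Compound 4 therefore cannot be ranked against compound 1, compound 2 or compound 3, although compound 2 and compound 1 differ beyond the scatter. Nothing available bears on a cause for these steps. Still open, going by these compounds, is whether a phenyl group carrying an amine or a carboxylic acid on this nitrogen would move the number beyond the scatter of compound 4.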